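Shortening the Amide Chain on a K562 Growth Inhibitor

The source may hold more compounds than are shown below. What is called first, only, known or untested is meant among the compounds shown, and "the series" means these compounds.

Compound 1, `CC[C@@H]1C(=O)N(C)c2cnc(-n3ccc4cc(F)ccc43)nc2N1C1CCCC1`: 21200 nM
Compound 2, `CC[C@@H]1C(=O)N(C)c2cnc(-n3ccc4cc(C(=O)NC(C)C)ccc43)nc2N1C1CCCC1`: 786 nM
Compound 3, `CCCNC(=O)c1ccc2c(ccn2-c2ncc3c(n2)N(C2CCCC2)[C@H](CC)C(=O)N3C)c1`: 395 nM

Three compounds share one core and differ in a single group. In a functional assay on K562 cells (Homo sapiens) for antiproliferative activity, read by CCK-8 assay, with a stated time of 72 h (on this read-out higher numbers stand for weaker inhibition of growth and lower numbers for stronger inhibition of growth), compound 1 gives 21200 nM. Putting an isopropylcarbamoyl in place of the fluoro gives a 27-fold lower number from compound 1 to compound 2 (1.43 log units; beyond the scatter), and a propylcarbamoyl gives a 54-fold lower number from compound 1 to compound 3 (1.73 log units; beyond the scatter). Compound 3 thus has the lowest number of the three, but its gap to compound 2, a 2.0-fold lower number from compound 2 to compound 3 (0.30 log units; within the scatter), is within the scatter, so the two cannot be ranked against each other.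

Compound 4, `CCNC(=O)c1ccc2c(ccn2-c2ncc3c(n2)N(C2CCCC2)[C@H](CC)C(=O)N3C)c1`, is the next step: hydrogen in place of methyl on a saturated chain carbon, two bonds along the chain from an amide-type nitrogen. Among the measured compounds shown here, the only measured step that bears on this is the swap of the group on the amide nitrogen, a 2.0-fold lower number from compound 2 to compound 3 (0.30 log units; within the scatter), which was within the scatter. Another small trim of that chain is therefore expected to give no step beyond the scatter, and the expected step is a 1.3-fold higher number from compound 3 to compound 4 (0.10 log units; within the scatter). The estimate for compound 4 is 500 nM, with a range from 200 nM to 1300 nM.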

Compound 4, concentration for 50% growth inhibition: 428 nM
Beside the measured number, compound 4's estimate is 1.2-fold (0.07 log units) above it, and the stated range covers the measured number.
By their numbers in this assay, from the lowest: compounds 3, 4 and 2 (each within the scatter of the next); then compound 1.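

Cutting the propylcarbamoyl down to an ethylcarbamoyl leaves the number in this assay within the scatter (a 1.1-fold higher number from compound 3 to compound 4 (0.03 log units; within the scatter)), and the same holds for the isopropylcarbamoyl against the ethylcarbamoyl (a 1.8-fold lower number from compound 2 to compound 4 (0.26 log units; within the scatter)), so these three amides cannot be ranked against one another. The large step away from the fluoro compound survives with the shortest chain shown (a 50-fold lower number from compound 1 to compound 4 (1.69 log units; beyond the scatter)), so among these four compounds the clear difference lies between fluoro and a carbamoyl group, with no compound going against it, while the chain on the amide nitrogen makes no readable difference. No measurement shown gives a reason for either observation.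

The compounds shown leave open whether a longer chain such as butyl, or a chain ending in an amine, would stay in this range. They also leave open whether a carboxylic acid in place of the fluoro would do as well as these amides.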